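The compounds below may be only part of what the source reports. "The series", "measured", "known", "first", "only" and "open" are said of these compounds alone.

Measured so far in an in vitro assay on SH-EP1 cells for displacement of a labelled ligand from Neuronal acetylcholine receptor; alpha4/beta2 (Homo sapiens); a lower number here means a stronger inhibitor, a higher number a weaker inhibitor:
compound 1 `Fc1ccc(C2=CC3CNCC(C2)C3)cn1` gives 0.4 nM
compound 2 `CC(C)Oc1cncc(C2=CC3CNCC(C2)C3)c1` gives 0.26 nM

Of these two numbers, compound 2 has the lower one, but its gap to compound 1 lies within the scatter, so no order between the two can be read. Compound 3 `C1=C(c2cccnc2)CC2CNCC1C2` differs from compound 2 in one place: hydrogen in place of isopropoxy on an aromatic carbon. Both substituents tried at this place have given low numbers, and nothing measured shows what the bare ring does there. The step from compound 2 to compound 3 in this assay is expected to be small, toward a somewhat higher number, estimated as a 2.3-fold higher number from compound 2 to compound 3 (0.36 log units; beyond the scatter). Compound 3 is therefore expected to give about 0.6 nM, within 0.15 nM to 2.5 nM.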

Compound 3, inhibition constant: 0.2 nM
Compound 3: middle estimate off by 3.0-fold (0.48 log units), on the high side, within the range that was stated.
By their numbers in this assay, from the lowest: compounds 3, 2 and 1 (each within the scatter of the next).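

In this assay the step of a 1.3-fold lower number from compound 2 to compound 3 (0.11 log units; within the scatter) shows that the aromatic carbon that carried isopropoxy keeps a low number with only hydrogen on it, so the bare ring cannot be told apart from the substituted one. Hydrogen in place of fluoro gives a 2.0-fold lower number from compound 1 to compound 3 (0.30 log units; within the scatter) and is likewise within the scatter, so neither substituent is shown to be needed for a low number. Nothing available explains this result. Still open, as far as these compounds go, is whether an amine, a carboxylic acid or a longer alkoxy chain on that carbon would leave the number as low.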